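The source may report more compounds than this note shows. Statements on the series, on what has been measured and on what is new or still open speak of the compounds shown alone.

Measured so far:
compound 1 `O=c1ccoc2cc(OCc3cn(Cc4cccc(Br)c4)nn3)ccc12`, a functional assay on A549 cells (Homo sapiens) for cytotoxicity, read by MTT assay, with a stated time of 48 h; a higher number here means a weaker inhibitor, a lower number a stronger inhibitor: > 100000 nM
compound 2 `O=c1ccoc2cc(OCc3cn(Cc4ccc(F)cc4)nn3)ccc12`, this assay: > 100000 nM

Compound 2 shows only a limit in this assay, > 100000 nM, and not a number. Compound 1 likewise gives only a limit there, > 100000 nM. Both values therefore sit at the limit of > 100000 nM in this assay, at which 2 of the 2 values shown sit, and the step that the two limits leave unreadable from compound 1 to compound 2 cannot be read from them.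

Compound 3 `O=c1ccoc2cc(OCc3cn(Cc4cccc(Cl)c4)nn3)ccc12` differs from compound 2 in one place: 3-chlorophenyl in place of 4-fluorophenyl on a saturated chain carbon bound to an aromatic nitrogen. Going by the values given here, the only measured step that touches this position, a step that the two limits leave unreadable from compound 1 to compound 2, stays unreadable because both of its ends rest on (the limit of > 100000 nM in this assay, at which 2 of the 2 values shown sit), so no direction or size is given by the data. Compound 3 is accordingly expected to change by about a step that the limit leaves unreadable from compound 2 to compound 3, that is, no readable step, and is most likely to end at the limit again. The estimate for compound 3 in this assay is 150000 nM, within a range of 50000 nM to 500000 nM.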

Compound 3, half-maximal inhibitory concentration: 13700 nM
Beside the measured number, compound 3's estimate is 11-fold (1.04 log units) above it; measured number outside the range, below it.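

In this assay, the position on a saturated chain carbon bound to an aromatic nitrogen now gives a readable change, with 3-chlorophenyl in place of 4-fluorophenyl producing an at least 7.2-fold lower number from compound 2 to compound 3 (0.86 log units; beyond the scatter). The change of chloro in place of bromo on an aromatic carbon gives an at least 7.2-fold lower number from compound 1 to compound 3 (0.86 log units; beyond the scatter), so in this pair the number responds to the halogen alone. Both sizes are only minimum sizes, as the starting compound of each step rests on a limit: the limit of > 100000 nM in this assay, at which 2 of the 3 values shown sit.

The compounds shown leave open whether 4-chlorophenyl or 3-fluorophenyl would behave like 3-chlorophenyl, which would separate the choice of halogen from its place on the ring. They also leave open how a phenyl ring carrying a methoxy group or an amine would read at this position.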